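This account rests on a few compounds, and the source may have more. Where it says the series, first, only, none or still open, it means among the compounds named here.

Values in a functional assay on NCI-H69 cells (Homo sapiens) for cytotoxicity; a lower number here means a stronger inhibitor, a higher number a weaker inhibitor

- Compound 1 `C[C@H]1C[C@H]1C1=N[C@H](/C=C\CCc2ccccc2)CS1` gives 34.1 ug/mL
- Compound 2 `CCCCCCCc1cccc(CC/C=C\[C@@H]2CSC([C@@H]3C[C@@H]3C)=N2)c1` gives 64.7 ug/mL

Compound 1 has the lower of these two numbers, but the gap to compound 2 lies within the scatter, so the two stand level. Next in line is compound 3 `CCCCCCc1ccc(CC/C=C\[C@@H]2CSC([C@@H]3C[C@@H]3C)=N2)cc1`, with the change (hexyl in place of hydrogen on an aromatic carbon), that is, hexyl in place of hydrogen on an aromatic carbon, para to a large group. Within the data shown here, only one measured step bears on it, the heptyl replacement in compound 2: a 1.9-fold higher number from compound 1 to compound 2 (0.28 log units; within the scatter). Among the measured compounds shown here, no hexyl compound has been measured, and this single comparison is thin support. On that basis, no step beyond the scatter is expected in this assay, though a small rise in the number would fit compound 2. The estimated step is a 1.5-fold higher number from compound 1 to compound 3 (0.17 log units; within the scatter). For compound 3 the expected value is 50 ug/mL, with an estimated range of 22 ug/mL to 110 ug/mL.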

Compound 3, half-maximal inhibitory concentration: 76.5 ug/mL
Beside the measured number, compound 3's estimate is 1.5-fold (0.18 log units) below it; the range from low to high includes it.
By their numbers in this assay, from the lowest: compounds 1, 2 and 3 (each within the scatter of the next, the first and the last beyond it).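

Adding a hexyl group to the aromatic ring, para to a large group, gives a 2.2-fold higher number from compound 1 to compound 3 (0.35 log units; beyond the scatter) in this assay, a modest step and the first one from compound 1 that lies beyond the scatter. A long alkyl chain at this position therefore brings no lower number here, and the heptyl step a 1.9-fold higher number from compound 1 to compound 2 (0.28 log units; within the scatter) stays within the scatter, so it neither adds to nor goes against this reading. No evidence at hand accounts for the step.

Compounds 2 and 3 differ in more than one place, so the separate contributions of chain length and ring position remain unresolved. Also open, going by these compounds, is whether a short methyl group, an amine or a carboxylic acid on the same aromatic carbon would lower the number or raise it further.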